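The source may report more compounds than this note shows. Statements on the series, on what has been measured and on what is new or still open speak of the compounds shown alone.

Compound 2, with the structure `COC(=O)C1=C(C)N=C(C)/C(=C(/O)OC)C1c1cccc(N/C(=N/CCNC2CCN(c3ccccc3C#N)CC2)NC#N)c1`, gives 3 nM in an assay on SK-N-MC cells for inhibition of Neuropeptide Y receptor type 1 (Homo sapiens) (a lower number here means a stronger inhibitor, a higher number a weaker inhibitor), and this is the lowest of the three numbers measured here. Compound 1, `COC(=O)C1=C(C)N=C(C)/C(=C(/O)OC)C1c1cccc(N/C(=N/CCNC2CCN(c3ccccc3[N+](=O)[O-])CC2)NC#N)c1`, gives 4 nM in this assay, so the pair sits within the scatter: a 1.3-fold lower number from compound 1 to compound 2 (0.12 log units; within the scatter). Compound 3, `COC(=O)C1=C(C)N=C(C)/C(=C(/O)OC)C1c1cccc(N/C(=N/CCNC2CCN(c3ccccc3OC(F)(F)F)CC2)NC#N)c1`, gives 28 nM, and here the gap is real: a 9.3-fold higher number from compound 2 to compound 3 (0.97 log units; beyond the scatter), with the matching step a 7.0-fold higher number from compound 1 to compound 3 (0.85 log units; beyond the scatter).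

Compound 4 is the structure `COC(=O)C1=C(C)N=C(C)/C(=C(/O)OC)C1c1cccc(N/C(=N/CCNC2CCN(c3ccccc3SC)CC2)NC#N)c1`, not yet measured. It differs from compound 2 by one exchange: methylsulfanyl in place of cyano on an aromatic carbon. Going by the values given here, the steps that bear on this are those at the same aromatic carbon. Swapping nitro for cyano changed nothing beyond the scatter, while swapping either of them for trifluoromethoxy raised the number beyond the scatter, as the steps above show. A group in the same place, neither nitro nor cyano, is therefore expected to cost something, though there is no basis for saying how much. The expected step is a 3.3-fold higher number from compound 2 to compound 4 (0.52 log units; beyond the scatter), and compound 4 is estimated at 10 nM, within a range of 3 nM to 35 nM.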

Compound 4, half-maximal inhibitory concentration: 3 nM
Estimate against measurement, compound 4: 3.3-fold (0.52 log units) above; measured number inside the range.
By their numbers in this assay, from the lowest: compounds 2, 4 and 1 (each within the scatter of the next); then compound 3.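

In this assay, the exchange of cyano for methylsulfanyl gives no change at the digits printed from compound 2 to compound 4 (within the scatter), and the exchange of nitro for methylsulfanyl gives a 1.3-fold lower number from compound 1 to compound 4 (0.12 log units; within the scatter), so this aromatic carbon accepts a third group without a change beyond the scatter, and the triple bond of cyano is not required to keep the number this low. Trifluoromethoxy is now the one group of the four that stands apart, with a 9.3-fold lower number from compound 3 to compound 4 (0.97 log units; beyond the scatter). Nothing measured here explains why these three groups match while trifluoromethoxy does not.

Still open, as far as these compounds go, is whether methoxy, a chlorine atom or a longer chain such as ethylsulfanyl at this carbon would stay with the three low numbers or move towards trifluoromethoxy. Also open, from the compounds shown here alone, is whether methylsulfanyl and cyano would still match on a different core.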